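Pyrazolo-fused series: propyl against trifluorobenzyl at the pyrazole

The source may hold more compounds than are shown below. What is called first, only, known or untested is meant among the compounds shown, and "the series" means these compounds.

Measured so far:
compound 1 `CCCc1nn(-c2nc(N)c3c(n2)NC(=O)C3(C)C)c2ccc(Cl)cc12` — 546000 nM
compound 2 `Nc1nc(-n2nc(Cc3ccccc3F)c3ccccc32)nc2c1CC(=O)N2` — 160 nM

In an assay on CHO cells for activation of soluble guanylate cyclase alpha1/beta1 complex (Homo sapiens), read by cGMP accumulation (on this read-out higher numbers stand for an effect only at larger amounts of compound and lower numbers for an effect already at smaller amounts), compound 1 gives 546000 nM, the highest of the two numbers in hand. Compound 2 differs from compound 1 in several places at once; in this assay compound 2 gives 160 nM. The gap between the two values lies beyond the usual scatter, and since more than one feature changes, no single-site step can be read from the pair.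

Compound 3 `CC1(C)C(=O)Nc2nc(-n3nc(Cc4c(F)ccc(F)c4F)c4cc(Cl)ccc43)nc(N)c21` is still to be measured. It departs from compound 1 in one place: 2,3,6-trifluorophenyl in place of ethyl on a saturated chain carbon bound to an aromatic carbon. Among the compounds with values here, no step of this kind between measured compounds is available, so the direction has to be taken from the broader comparison: compound 2, the only compound carrying a benzyl-type group on the pyrazole, gives 160 nM, far below compound 1, which carries a plain propyl. On that basis a large step toward lower numbers is expected for a 910-fold lower number from compound 1 to compound 3 (2.96 log units; beyond the scatter). The uncertainty is wide because compound 1 at 546000 nM is the only anchor for this core. Compound 3 is estimated at 600 nM, within 60 nM to 8000 nM.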

Compound 3, half-maximal effective concentration: 7300 nM
For compound 3 the middle estimate is 12-fold (1.09 log units) below the measured one; measured number inside the range.
By their numbers in this assay, from the lowest: compound 2; then compound 3; then compound 1.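

In this assay the place on a saturated chain carbon bound to an aromatic carbon now has its first single-site step: going from propyl to 2,3,6-trifluorobenzyl gives a 75-fold lower number from compound 1 to compound 3 (1.87 log units; beyond the scatter) with the rest of the structure unchanged. This step lies beyond the usual scatter, so the value at this place responds to the change on the shared core, which the earlier pair, differing in several places at once, could not show. No supporting data bear on why the step has this size.

The compounds shown leave open whether the lower number depends on the aromatic ring alone or also on its fluorines, a question that an unsubstituted benzyl at this place on the same core would address, while a longer chain such as butyl would test whether chain length alone has any effect. Steps to compound 2 cannot be read, since it differs from both compound 1 and compound 3 in several places, so the contribution of its other features also remains open.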